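Adding 4-methylphenyl to the ring nitrogen of compound 3

The source may hold more compounds than are shown below. What is called first, only, known or untested is meant among the compounds shown, and "the series" means these compounds.

Measured in a functional assay on HepG2 cells (Homo sapiens) for antiproliferative activity, read by MTT assay, with a stated time of 72 h; a lower number here means a stronger inhibitor, a higher number a weaker inhibitor:
compound 1 `CC(C)N1C(=O)COc2ccc(-c3cnc(Cl)c(NS(=O)(=O)c4ccc(F)cc4)c3)cc21` gives 21500 nM
compound 2 `O=C1COc2ccc(-c3cnc(Cl)c(NS(=O)(=O)c4ccc(F)cc4)c3)cc2N1c1ccc(F)cc1` gives > 40000 nM (a limit, not a number)
compound 3 `O=C1COc2ccc(-c3cnc(Cl)c(NS(=O)(=O)c4ccc(F)cc4)c3)cc2N1` gives > 40000 nM (a limit, not a number)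

Compound 3 therefore stands at a limit and has no exact value. Compound 4 `Cc1ccc(N2C(=O)COc3ccc(-c4cnc(Cl)c(NS(=O)(=O)c5ccc(F)cc5)c4)cc32)cc1` differs from it by 4-methylphenyl in place of hydrogen on an amide-type nitrogen in a ring with 4-methylphenyl in place of hydrogen on an amide-type nitrogen in a ring. The closest measured change is a step that the two limits leave unreadable from compound 2 to compound 3 with hydrogen in place of 4-fluorophenyl, and its size cannot be read. Replacing isopropyl gave an at least 1.8-fold higher number from compound 1 to compound 2 (0.26 log units; that floor lies within the scatter) with 4-fluorophenyl and an at least 1.8-fold higher number from compound 1 to compound 3 (0.26 log units; that floor lies within the scatter) with hydrogen, both floors within the scatter. No step beyond the scatter is expected in this assay and the expected step is a step that the limit leaves unreadable from compound 3 to compound 4 on this estimate. The estimate for compound 4 is 45000 nM with an expected range of 20000 nM to 100000 nM in this assay.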

Compound 4, half-maximal inhibitory concentration: 39600 nM
For compound 4 the middle estimate is 1.1-fold (0.06 log units) above the measured one; the range from low to high includes it.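

In this assay, going by these compounds alone, compound 4 gives 39600 nM, the only exact value shown for an aromatic ring on this amide-type nitrogen. Exchanging isopropyl for 4-methylphenyl gives a 1.8-fold higher number from compound 1 to compound 4 (0.27 log units; within the scatter), so these two groups cannot be told apart here. Placing 4-methylphenyl in place of hydrogen gives a number no higher from compound 3 to compound 4 (the limit leaves the size open), and methyl in place of fluoro on an aromatic carbon gives a number no higher from compound 2 to compound 4 (the limit leaves the size open). The sizes of these two steps cannot be read because both start from a limit: the limit of > 40000 nM in this assay, at which 2 of the 4 values shown sit.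

Still open, from the compounds shown here alone, is whether any group on this nitrogen can bring the number clearly lower than in compound 1. An amine, a carboxylic acid or a longer chain at this position would test that.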